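Carboxy for Tert-Butyl: Expected Cytotoxicity of Compound 4

The source may report more compounds than this note shows. Statements on the series, on what has been measured and on what is new or still open speak of the compounds shown alone.

Compound 1 `CC(C)(C)c1ccc(C(=O)NNc2c(Br)cccc2Br)cc1` was tested in a toxicity assay on MDCK cells (Canis lupus familiaris) for cytotoxicity, read by CCK-8 assay, with a stated time of 48 h; on this read-out higher numbers stand for lower toxicity in this test and lower numbers for higher toxicity in this test. In this assay compound 1 gives > 100000 nM, which is a limit of the assay rather than a number. Two other compounds share that outcome. Compound 2 `COc1ccccc1C(=O)NNc1c(Br)cccc1Br` gives > 100000 nM in this assay, again a limit. Compound 3 `CCOc1ccc(C(=O)NNc2c(C)cccc2Cl)cc1` gives > 100000 nM in this assay, also a limit. Compound 1 therefore stands together with compound 2 and compound 3, and the whole evidence comes down to one observation: the limit of > 100000 nM in this assay, at which 3 of the 3 values shown sit. Among the measured compounds shown here, no step between measured compounds can be drawn, since none of the three differs from another in a single place.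

Compound 4 `O=C(O)c1ccc(C(=O)NNc2c(Br)cccc2Br)cc1` has not yet been measured in this assay. Compared with compound 1 it carries carboxy in place of tert-butyl on an aromatic carbon. With every measured compound sitting at the limit, no step beyond the scatter is expected in this assay in either direction, and compound 4 is expected to remain at the limit as well. The step that this estimate means, a step that the limit leaves unreadable from compound 1 to compound 4, is expected to be no change beyond the scatter. Compound 4 is expected to give about 150000 nM in this assay, within a range from 80000 nM to 300000 nM.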

Compound 4, half-maximal cytotoxic concentration: > 100000 nM
Compound 4: only a limit was reported; the forecaster's own chance of this, stated with the estimate: 85%; the middle value is on the limit's open side.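

In this assay compound 4 gives > 100000 nM, which is a limit of the assay. Compound 1 also stands at a limit, so no step can be read from compound 1 to compound 4. The compounds shown leave open whether carboxy and tert-butyl differ at all in this assay, as all that stands is one observation: the limit of > 100000 nM in this assay, at which 4 of the 4 values shown sit.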